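The compounds below may be only part of what the source reports. "The series", "measured", "known", "first", "only" and "open" are said of these compounds alone.

Values so far in a functional assay on MV4-11 cells (Homo sapiens) for inhibition, read by resazurin assay, with a stated time of 72 h (on this read-out lower numbers stand for stronger inhibition of growth and higher numbers for weaker inhibition of growth), are these:

- compound 1 `CNc1nc(C)c(-c2ccnc(Nc3ccc(OC)cc3OC)n2)s1` gives 300 nM 
- compound 2 `CCCn1cc(-c2ccnc(Nc3ccc(OC)cc3OC)n2)c2ccccc21` gives 3620 nM 
- compound 3 `COc1ccc(Nc2nccc(-c3cn(C4CCCC4)c4ccccc34)n2)c(OC)c1` gives 1740 nM 

Compound 1 holds the lowest number of the three, and its gaps to compound 2 and compound 3 both lie beyond the scatter. Compound 4 `CCCCOc1nc(C)c(-c2ccnc(Nc3ccc(OC)cc3OC)n2)s1` differs from compound 1 by one change butoxy in place of methylamino on an aromatic carbon on the five-membered aromatic ring with 1 nitrogen and 1 sulfur.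

Within the data shown here, the only measured step is a 2.1-fold lower number from compound 2 to compound 3 (0.32 log units; beyond the scatter) and it is modest. It swaps cyclopentyl for propyl on an aromatic nitrogen, so it is a different change in a different place and bears only loosely here. Among the measured compounds shown here, no measured compound carries butoxy, and nothing yet shows what methylamino contributes. For the measured compounds named here, with compound 1 at 300 nM as the lowest number so far, a moderate step to a higher number in this assay is expected, though a step within the scatter remains possible. For compound 4 the estimated value is 800 nM with an expected range from 250 nM to 2500 nM as the working figure. The estimate amounts to an expected 2.7-fold higher number from compound 1 to compound 4 (0.43 log units; beyond the scatter) for now.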

Compound 4, concentration for 50% growth inhibition: 7860 nM
Beside the measured number, compound 4's estimate is 9.8-fold (0.99 log units) below it, outside the stated range (above it).
By their numbers in this assay, from the lowest: compound 1; then compound 3; then compound 2; then compound 4.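

In this assay, butoxy in place of methylamino on this aromatic carbon, next to the ring nitrogen and next to the ring sulfur, gives a 26-fold higher number from compound 1 to compound 4 (1.42 log units; beyond the scatter), so the group at this position has a large bearing on the read-out. The change removes the hydrogen-bond donor of methylamino, replaces nitrogen with oxygen as the attached atom and lengthens the chain, and this single step cannot separate these differences. No measurement available here explains the step.

The compounds shown leave open whether the step follows from the loss of the amine nitrogen or from the longer chain. Methoxy, with a short chain on oxygen, and butylamino, with the longer chain on nitrogen, would separate the two, while a free amine would show whether the methyl group of methylamino matters.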